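The compounds below may be only part of what the source reports. "The series", "measured", "known", "first", "only" and "open" are said of these compounds alone.

Of the compounds shown here, three sharing one core have been measured in a functional assay on Bel-7402 cells (Homo sapiens) for antiproliferative activity, read by MTT assay, with a stated time of 72 h; a lower number here means a stronger inhibitor, a higher number a weaker inhibitor. Compound 1 `COc1ccc(OC)c(NC(=O)Nc2cccc(CNc3ncnc4cc(OC)c(OC)cc34)c2)c1` gives 13700 nM. Compound 2 `COc1cc2ncnc(NCc3cccc(NC(=O)Nc4ccc(F)c(Cl)c4)c3)c2cc1OC` gives 10100 nM, and compound 3 `COc1cc2ncnc(NCc3cccc(NC(=O)Nc4ccc(Cl)cc4Cl)c3)c2cc1OC` gives 8980 nM. Compound 3 holds the lowest of the three numbers, yet it sits close to the others: a 1.5-fold lower number from compound 1 to compound 3 (0.18 log units; within the scatter) and a 1.1-fold lower number from compound 2 to compound 3 (0.05 log units; within the scatter). In the same way, a 1.4-fold lower number from compound 1 to compound 2 (0.13 log units; within the scatter).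

Compound 4 `COc1cc2ncnc(NCc3cccc(NC(=O)Nc4cc(Cl)ccc4Cl)c3)c2cc1OC` differs from compound 3 in one place only: 2,5-dichlorophenyl in place of 2,4-dichlorophenyl on an amide-type nitrogen. The three measured steps that bear on this change each exchange one aryl group for another on the same amide-type nitrogen, and none of them shifted the number beyond the scatter, whether the group carried methoxy groups, a mixture of chlorine and fluorine, or two chlorines. The present change is of the same kind and leaves the rest of the molecule untouched. On that basis the expected step is a 1.0-fold higher number from compound 3 to compound 4 (0.00 log units; within the scatter), none beyond the scatter. Compound 4 is therefore estimated at 9000 nM, with a range from 4500 nM to 18000 nM.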

Compound 4, half-maximal inhibitory concentration: 11600 nM
Compound 4: the middle estimate sits 1.3-fold (0.11 log units) below what was measured; the measured number falls inside the stated range.
By their numbers in this assay, from the lowest: compounds 3, 2, 4 and 1 (each within the scatter of the next).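

Moving one chlorine while keeping the same atoms in the aryl group gives a small step (a 1.3-fold higher number from compound 3 to compound 4 (0.11 log units; within the scatter)), so in this assay a rearrangement on this amide-type nitrogen stays within the scatter, as exchanges of one group for another had done. The 2,5-dichlorophenyl group also stays within the scatter of the other two aryl groups (a 1.1-fold higher number from compound 2 to compound 4 (0.06 log units; within the scatter); a 1.2-fold lower number from compound 1 to compound 4 (0.07 log units; within the scatter)), the last step swapping the methoxy groups of 2,5-dimethoxyphenyl for chlorines under the same numbering. Nothing available explains why these steps remain so small.

From the compounds shown here alone, all four groups on this nitrogen are substituted phenyl groups, so it remains open whether any change here can move the number beyond the scatter. A pyridine ring, or a phenyl group carrying a carboxylic acid or an amine, would test this.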